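The source may report more compounds than this note shows. Statements on the series, on what has been measured and on what is new or still open speak of the compounds shown alone.

In a functional assay on CHO cells for antagonist activity at corticotropin-releasing factor receptor 1 (Homo sapiens), read by cAMP accumulation (on this read-out lower numbers stand for stronger inhibition and higher numbers for weaker inhibition), the three measured compounds stand as follows:
compound 1 `CCCNCc1noc(Nc2nc(C)nc3c2c(C)nn3-c2ccc(OC)cc2C)n1` gives 84 nM
compound 2 `CCC[C@H](CO)Nc1nc(C)nc2c1c(C)nn2-c1ccc(OC)cc1C` gives 76 nM
compound 3 `CCC[C@@H](CO)Nc1nc(C)nc2c1c(C)nn2-c1ccc(OC)cc1C` gives 574 nM

Compound 1 sits second highest of the three numbers. Its nearest neighbour is compound 2, with a 1.1-fold lower number from compound 1 to compound 2 (0.04 log units; within the scatter), a difference that stays within the scatter. Its furthest is compound 3, with a 6.8-fold higher number from compound 1 to compound 3 (0.83 log units; beyond the scatter). Between compound 2 and compound 3 the gap is a 7.6-fold higher number from compound 2 to compound 3 (0.88 log units; beyond the scatter), and this rests on (the fact that compounds 2 and 3 differ only in the configuration as drawn), so the configuration at the saturated chain carbon alone moves the number by a modest amount.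

Compound 4 `CCC(CC)Nc1nc(C)nc2c1c(C)nn2-c1ccc(OC)cc1C` is the next compound in this series. Relative to compound 1 the change is pentan-3-yl in place of 3-((propylamino)methyl)-1,2,4-oxadiazol-5-yl on a nitrogen on an aromatic ring. The measured steps that bear on it are the two replacements of the same oxadiazole group by a branched saturated chain at the same nitrogen: one within the scatter, the other a modest rise. Compound 4 carries a branched chain of the same length but without a hydroxyl and without a stereocentre, so the step from compound 1 to compound 4 in this assay is expected to be small, a 1.4-fold lower number from compound 1 to compound 4 (0.15 log units; within the scatter), in either direction rather than a clear loss. Compound 4 is therefore estimated at 60 nM, in a range from 15 nM to 250 nM.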

Compound 4, inhibition constant: 42 nM
For compound 4 the middle estimate is 1.4-fold (0.15 log units) above the measured one; the measured number falls inside the stated range.
By their numbers in this assay, from the lowest: compounds 4, 2 and 1 (each within the scatter of the next); then compound 3.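

In this assay, pentan-3-yl, with no ring and 0 hydrogen-bond donors or acceptors, can replace 3-((propylamino)methyl)-1,2,4-oxadiazol-5-yl with a 2.0-fold lower number from compound 1 to compound 4 (0.30 log units; within the scatter), and it can replace 1-(hydroxymethyl)butyl with a 1.8-fold lower number from compound 2 to compound 4 (0.26 log units; within the scatter). Among these compounds, then, a plain saturated branched chain on this nitrogen matches both larger groups within the scatter, so neither the five-membered aromatic ring nor the hydroxyl is needed to reach this level. Against compound 3 the same change gives a 14-fold lower number from compound 3 to compound 4 (1.14 log units; beyond the scatter), which shows that the weak number of compound 3 does not belong to branched chains at this position in general but goes with the configuration of its one stereocentre, because of this: the fact that compounds 2 and 3 differ only in the configuration as drawn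

Still open, on these data alone, is whether a longer chain, such as heptan-4-yl, or a small ring, such as cyclopentyl, would hold the number at this nitrogen. As far as these compounds go, it is also open whether a primary amine or a carboxylic acid in place of the hydroxyl would keep the same dependence on configuration.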